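A few compounds are considered here, and "the series" means these few. Any claim that something is new, unique, unknown or untested is made for them only; others in the source may bear on it.

Measured compounds:
- compound 1 `O=C(Nc1ccnnc1)c1cc(N2CCC(F)CC2)ccc1OCc1ccccc1`: 39.8 nM
- compound 2 `C[C@@H]1CN(c2ccc(OCc3ccccc3)c(C(=O)Nc3ccnnc3)c2)C[C@H](C)O1`: 20 nM

Among the measured compounds shown here, in an assay on Sf9 cells for inhibition of Leucine-rich repeat serine/threonine-protein kinase 2 (Homo sapiens), read by TR-FRET, with stated times of 30 min and 2 h (on this read-out higher numbers stand for weaker inhibition and lower numbers for stronger inhibition), compound 2 stands at the lowest of the two numbers so far, with compound 1 its only neighbour; the gap between them, a 2.0-fold lower number from compound 1 to compound 2 (0.30 log units; within the scatter), is within the scatter, so the two cannot be ordered.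

Compound 3 `CN1CCN(c2ccc(OCc3ccccc3)c(C(=O)Nc3ccnnc3)c2)CC1` carries the change (4-methylpiperazin-1-yl in place of 2,6-dimethylmorpholin-4-yl on an aromatic carbon). For the measured compounds named here, the only comparable step is that from compound 1 to compound 2, where one saturated ring amine was exchanged for another at the same place and the reading moved by a 2.0-fold lower number from compound 1 to compound 2 (0.30 log units; within the scatter), that is, not beyond the scatter. On that basis the exchange for the 4-methylpiperazin-1-yl group is expected to give no step beyond the scatter in this assay, and the expected step is a 1.3-fold higher number from compound 2 to compound 3 (0.10 log units; within the scatter). Compound 3 is therefore estimated at 25 nM, with a range of 8 nM to 80 nM.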

Compound 3, half-maximal inhibitory concentration in the Leucine-rich repeat serine/threonine-protein kinase 2 assay: 12.6 nM
Estimate against measurement, compound 3: 2.0-fold (0.30 log units) above; measured number inside the range.
By their numbers in the Leucine-rich repeat serine/threonine-protein kinase 2 assay, from the lowest: compounds 3, 2 and 1 (each within the scatter of the next, the first and the last beyond it).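

In the Leucine-rich repeat serine/threonine-protein kinase 2 assay this position now gives a step beyond the scatter, though a modest one, a 3.2-fold lower number from compound 1 to compound 3 (0.50 log units; beyond the scatter). The other new step, a 1.6-fold lower number from compound 2 to compound 3 (0.20 log units; within the scatter), does not separate the two groups, so 4-methylpiperazin-1-yl can be ordered against 4-fluoropiperidin-1-yl but not against 2,6-dimethylmorpholin-4-yl. In a physicochemical assay for lipophilicity, at pH 7.4 (a lower number here means a more polar compound, a higher number a more lipophilic compound), compound 2 gives 5.4 and compound 3 gives 3. With no step beyond the scatter in the Leucine-rich repeat serine/threonine-protein kinase 2 assay, the exchange of 2,6-dimethylmorpholin-4-yl for 4-methylpiperazin-1-yl still gives a far more polar compound in the physicochemical assay: the measured distribution coefficient of compound 2, 5.4, and of compound 3, 3, a number 2.40 log units lower (beyond the scatter)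

Open, going by these compounds, is how an open-chain amine such as dimethylamino, or a carboxylic acid, would read at this position. Also open, on these data alone, is whether the methyl group of 4-methylpiperazin-1-yl matters to the reading, as against an acetyl group on the same nitrogen.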